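The source may report more compounds than this note shows. Statements on the series, on what has been measured and on what is new or still open speak of the compounds shown alone.

In an ADME assay (Rattus norvegicus) for inhibition (on this read-out higher numbers stand for weaker inhibition and lower numbers for stronger inhibition), the measured compounds stand as follows:

Compound 1 `Cc1nc2c([nH]1)C(=O)/C(=N/c1cccc(Cl)c1)C(Cl)=C2O`: 900 nM
Compound 2 `Cc1nc2c([nH]1)C(=O)/C(=N/c1cccc(Br)c1)C(Cl)=C2O`: 1000 nM
Compound 3 `Cc1nc2c(nc1C)C(=O)C(Nc1ccc(Cl)cc1)=CC2=O`: 3300 nM

Compound 1 and compound 2 share one core and differ only in bromo in place of chloro on an aromatic carbon. That change brought a 1.1-fold higher number from compound 1 to compound 2 (0.05 log units; within the scatter), so the two compounds cannot be ordered against each other in this assay. Compound 3 is built on a different core; the difference between the two cores is not broken down here. Its value in this assay is the highest of the three, beyond the scatter from both compound 1 and compound 2.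

Compound 4 `Cc1nc2c(nc1C)C(=O)C(Nc1ccc(Br)cc1)=CC2=O` is not yet measured. It differs from compound 3 in bromo in place of chloro on an aromatic carbon. Among the compounds with values here, this is the same kind of change as the one from compound 1 to compound 2, but not the same: there the bromo stood meta to a large group, here it stands para to a large group. The step of a 1.1-fold higher number from compound 3 to compound 4 (0.03 log units; within the scatter) is expected to be small, because the matching step a 1.1-fold higher number from compound 1 to compound 2 (0.05 log units; within the scatter) stayed within the scatter. On that basis compound 4 is estimated at 3500 nM in this assay, with a likely range from 1700 nM to 7200 nM.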

Compound 4, half-maximal inhibitory concentration: 1100 nM
Compound 4: middle estimate off by 3.2-fold (0.50 log units), on the high side; measured number outside the range, below it.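

In this assay, bromo in place of chloro, read here as 4-chlorophenyl to 4-bromophenyl, gave a 3.0-fold lower number from compound 3 to compound 4 (0.48 log units; beyond the scatter), a modest step, whereas the same kind of exchange on the other core gave a 1.1-fold higher number from compound 1 to compound 2 (0.05 log units; within the scatter). The size of this change therefore did not carry from one core to the other in this series: the same change on two cores in this assay, a 1.1-fold higher number (0.05 log units; within the scatter) from compound 1 to compound 2 and a 3.0-fold lower number (0.48 log units; beyond the scatter) from compound 3 to compound 4, 3.3-fold (0.52 log units) apart, beyond the scatter of two such steps. This does not show why the steps differ, since the two pairs differ in their core and also in where the halogen stands on the aromatic ring, and two pairs give no rule for any further core.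

From the compounds shown here alone, it remains open whether a bromo para to a large group on the core of compound 1 would give a step like the one seen on the core of compound 3. Also open, going by these compounds, is how a fluoro, a methoxy or an amine in that same place on the core of compound 3 would compare with chloro and bromo.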